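The source may report more compounds than this note shows. Statements on the series, on what has been measured and on what is new or still open speak of the compounds shown alone.

Values so far in a functional assay on MCF7 cells (Homo sapiens) for inhibition, read by sulforhodamine B assay (on this read-out higher numbers stand for weaker inhibition and lower numbers for stronger inhibition), for the shared core:
- compound 1 `O=C1C(Nc2ccccc2)=CC(=O)c2c1nc1n2[C@H]2OC[C@@H](O)[C@H]2OC1` gives > 4000 nM which is a limit and not a number
- compound 2 `O=C1C=C(Nc2ccccc2F)C(=O)c2c1nc1n2[C@H]2OC[C@@H](O)[C@H]2OC1` gives 3640 nM
- compound 3 `Cc1ccc(NC2=CC(=O)c3c(nc4n3[C@H]3OC[C@@H](O)[C@H]3OC4)C2=O)cc1C` gives 4950 nM

Compound 2 stands at 3640 nM and compound 3 at 4950 nM within the scatter of it, so these two numbers cannot be put in order.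

Compound 4 `CCOc1ccc(NC2=CC(=O)c3nc4n(c3C2=O)[C@H]2OC[C@@H](O)[C@H]2OC4)cc1` has not yet been measured. It has 4-ethoxyphenyl in place of 2-fluorophenyl on an amine nitrogen, the counted difference being 4-ethoxyphenyl in place of 2-fluorophenyl on an amine nitrogen and the rest of the structure unchanged.

Going by the values given here, the only measured step at this nitrogen is a step that the limit leaves unreadable from compound 1 to compound 3 and it offers no size to carry over. Among the compounds with values here, the one readable comparison is the pair of numbers for compound 2 and compound 3, which differ in the group on this nitrogen yet stay within the scatter. On that thin basis, no shift beyond the scatter is expected in this assay.

The expected change is a 1.1-fold higher number from compound 2 to compound 4 (0.04 log units; within the scatter) and it is an estimate with no firm direction. The estimated value for compound 4 is 4000 nM with an expected range from 1800 nM to 9000 nM as its span.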

Compound 4, half-maximal inhibitory concentration: 1430 nM
Estimate against measurement, compound 4: 2.8-fold (0.45 log units) above; the whole stated range lies above it.
By their numbers in this assay, from the lowest: compound 4; then compounds 2 and 3 (each within the scatter of the next).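

In this assay, going by these compounds alone, 4-ethoxyphenyl in place of 2-fluorophenyl on the amine nitrogen gives a 2.5-fold lower number from compound 2 to compound 4 (0.41 log units; beyond the scatter), the first readable step at this nitrogen beyond the scatter, though a modest one. The group on this nitrogen can therefore shift the number, which the close values of compound 2 and compound 3 did not show; the step removes the fluorine and brings in an oxygen counted as a hydrogen-bond acceptor, and this one pair cannot separate those changes. Compound 1 carries a limit and not a number, so steps from it cannot be read: the limit of > 4000 nM in this assay, at which 1 of the 4 values shown sits.

As far as these compounds go, whether the lower number goes with the oxygen or with the chain stays open; 4-methoxyphenyl and 4-butylphenyl on this nitrogen would tell these apart. Also open, from the compounds shown here alone, is how a basic amine on the phenyl ring would read here.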